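This account rests on a few compounds, and the source may have more. Where it says the series, first, only, none or still open, it means among the compounds named here.

In a functional assay on a cell-free system (Platelet, plasma, Homo sapiens) for inhibition (a lower number here means a stronger inhibitor, a higher number a weaker inhibitor), compound 1 `O=C(Nc1cccc(OCc2ccc(F)cc2)c1)C1CCNCC1` gives 68000 nM and compound 2 `O=C(Nc1cccc(OCc2ccc(-c3ccccc3)cc2)c1)C1CCNCC1` gives 111000 nM. Going by the values given here, these are the only two numbers available, and they lie within the scatter of each other, so compound 2 cannot be separated from compound 1. Compound 3 `O=C(Nc1cccc(OCc2ccc(-c3ccc(F)cc3)cc2)c1)C1CCNCC1` has not yet been measured. It differs from compound 2 by a single change, fluoro in place of hydrogen on an aromatic carbon, which turns phenyl into 4-fluorophenyl.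

Among the compounds with values here, only one measured step bears on this change. It is a 1.6-fold higher number from compound 1 to compound 2 (0.21 log units; within the scatter), and it put phenyl in place of fluoro on an aromatic carbon. That exchange involved a whole ring, yet it did not move the number beyond the scatter. Within the data shown here, it is a single step, and no measured pair shows what fluoro does on the outer ring, so the evidence is thin. Even so, no shift beyond the scatter is expected in this assay, and no direction can be argued. The expected size of the change is a 1.1-fold lower number from compound 2 to compound 3 (0.05 log units; within the scatter). For compound 3 the estimated value is 100000 nM, with an expected range of 50000 nM to 200000 nM.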

Compound 3, half-maximal inhibitory concentration: 35000 nM
Estimate against measurement, compound 3: 2.9-fold (0.46 log units) above; measured number outside the range, below it.
By their numbers in this assay, from the lowest: compounds 3, 1 and 2 (each within the scatter of the next, the first and the last beyond it).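

In this assay, going by these compounds alone, the outer ring of compound 2 responds to a single atom: fluoro in place of hydrogen, para to a large group, gives a 3.2-fold lower number from compound 2 to compound 3 (0.50 log units; beyond the scatter) and is the first step to pass beyond the scatter, though only modestly. The earlier exchange of phenyl for fluoro stayed within the scatter, and the step from the lone fluoro to the 4-fluorophenyl group, a 1.9-fold lower number from compound 1 to compound 3 (0.29 log units; within the scatter), does so as well, which means that compound 3 separates from compound 2 but not from compound 1. No measurement available here accounts for the effect of this fluoro.

The compounds shown leave open whether this step is particular to fluoro or would also appear with chloro, methoxy or a nitrile at the same place on the outer ring. They also leave open how an amine or a carboxylic acid would read there, and whether a second fluoro on that ring would carry the number further in the same direction.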